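Trimming the side chain: from compound 2 to compound 4

The source may report more compounds than this note shows. Statements on the series, on what has been measured and on what is new or still open speak of the compounds shown alone.

Measured so far:
- compound 1, `Cn1ncc(Cl)c1-c1cc(C(=O)N[C@H]2CNCC[C@@H]2c2ccc(C(F)(F)F)cc2)oc1Cl`: 900 nM
- compound 2, `Cn1ncc(Cl)c1-c1cc(C(=O)N[C@@H]2CN[C@H](CC(=O)NC3CC3)C[C@H]2c2ccc(Cl)c(Cl)c2)oc1Cl`: 580 nM
- compound 3, `CC(=O)NCC[C@@H]1C[C@@H](c2ccc(F)c(F)c2)[C@H](NC(=O)c2cc(-c3c(Cl)cnn3C)c(Cl)o2)CN1`: 880 nM

All three compounds were tested in a functional assay on OVCAR-8 cells (Homo sapiens) for antiproliferative activity; on this read-out lower numbers stand for stronger inhibition and higher numbers for weaker inhibition. Compound 2 gives the lowest of the three numbers, yet its gaps to compound 3 and to compound 1 both fall inside the usual scatter, so no order among them can be claimed. The three compounds share a core and differ in what is attached to the saturated ring and in what hangs from the ring on a chain, and these changes have not moved the numbers beyond the scatter.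

Compound 4, `C=CC[C@@H]1C[C@@H](c2ccc(Cl)c(Cl)c2)[C@H](NC(=O)c2cc(-c3c(Cl)cnn3C)c(Cl)o2)CN1`, has not been measured. Compared with compound 2, it carries vinyl in place of cyclopropylcarbamoyl on a saturated chain carbon bound to a saturated ring carbon. For the measured compounds named here, no single-point step between measured compounds is available to calibrate this kind of change, so the expectation rests on the flat spread of the three values shown. The step of a 1.6-fold higher number from compound 2 to compound 4 (0.19 log units; within the scatter) is therefore expected to be small, at most a mild weakening, and may well stay within the scatter. For compound 4 the estimate in this assay is 900 nM, with a plausible range from 400 nM to 2000 nM.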

Compound 4, half-maximal inhibitory concentration: 990 nM
Beside the measured number, compound 4's estimate is 1.1-fold (0.04 log units) below it; the measured number falls inside the stated range.
By their numbers in this assay, from the lowest: compounds 2, 3, 1 and 4 (each within the scatter of the next).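

In this assay, for the compounds shown here, the exchange gives the first comparison of compounds that differ in one place: a 1.7-fold higher number from compound 2 to compound 4 (0.23 log units; within the scatter). On a saturated chain carbon bound to a saturated ring carbon, the cyclopropylcarbamoyl of 6 heavy atoms, with its three-membered ring, hydrogen-bond donor and hydrogen-bond acceptor, gives way to a vinyl of 2 heavy atoms with none of these, and the two values still cannot be told apart. For this pair, then, the ring, the donor and the acceptor of the cyclopropylcarbamoyl are not needed to keep the number within the scatter, although no measurement here offers an explanation for this result.

The compounds shown leave open whether a saturated propyl chain at this place, or a chain ending in an amine or a carboxylic acid, would also stay within the scatter of compound 2. They also leave open whether the same exchange would give a similar step with a different group on the saturated ring, because this single pair carries only the dichlorophenyl of compound 2 and compound 4.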